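Chloro for fluoro on the pendant phenyl of compound 3

The source may hold more compounds than are shown below. What is called first, only, known or untested is meant among the compounds shown, and "the series" means these compounds.

Measured compounds:
compound 1, `Fc1ccc2c(Cn3cncn3)c(-c3ccc(Cl)cc3)[nH]c2c1`: 217 nM
compound 2, `Clc1ccc(-c2[nH]c3cc(Cl)ccc3c2Cn2cncn2)cc1`: 208 nM
compound 3, `COc1ccc2c(Cn3cncn3)c(-c3ccc(F)cc3)[nH]c2c1`: 238 nM

Of the compounds shown here, three sharing one core have been measured in an assay on isolated protein for inhibition of Aromatase (Homo sapiens), read by ELISA, using NADPH, with a stated time of 24 h; on this read-out higher numbers stand for weaker inhibition and lower numbers for stronger inhibition. Compound 3 gives the highest of the three numbers, yet its gaps to compound 1 and to compound 2 both lie within the scatter, so the three stand together and no order among them can be claimed.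

Compound 4, `COc1ccc2c(Cn3cncn3)c(-c3ccc(Cl)cc3)[nH]c2c1`, differs from compound 3 in one place: chloro in place of fluoro on an aromatic carbon. Among the measured compounds shown here, the one measured step of the same kind, chloro in place of fluoro on an aromatic carbon, is a 1.0-fold lower number from compound 1 to compound 2 (0.02 log units; within the scatter), a change that did not move the number beyond the scatter. For the measured compounds named here, with only that step to draw on, the expectation for compound 4 in this assay is a step of no size beyond the scatter, in no particular direction, and the estimated step is a 1.1-fold lower number from compound 3 to compound 4 (0.02 log units; within the scatter). Compound 4 is therefore expected to give about 225 nM, with a range from 120 nM to 420 nM.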

Compound 4, half-maximal inhibitory concentration: 7770 nM
Compound 4: middle estimate off by 35-fold (1.54 log units), on the low side, outside the stated range (above it).
By their numbers in this assay, from the lowest: compounds 2, 1 and 3 (each within the scatter of the next); then compound 4.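

In this assay, 4-fluorophenyl to 4-chlorophenyl is not a silent change on every core, for with methoxy on the shared core it gives a 33-fold higher number from compound 3 to compound 4 (1.51 log units; beyond the scatter). With the 4-chlorophenyl group held, the other substituent on the core also matters, as methoxy in place of chloro gives a 37-fold higher number from compound 2 to compound 4 (1.57 log units; beyond the scatter) and methoxy in place of fluoro gives a 36-fold higher number from compound 1 to compound 4 (1.55 log units; beyond the scatter). The effect of exchanging fluoro for chloro on the pendant phenyl therefore depends on the core that carries it, and the two steps lie far apart: the same change on two cores in this assay, a 1.0-fold lower number (0.02 log units; within the scatter) from compound 1 to compound 2 and a 33-fold higher number (1.51 log units; beyond the scatter) from compound 3 to compound 4, 34-fold (1.53 log units) apart, beyond the scatter of two such steps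

The compounds shown leave open whether a bromo or a methyl group on the pendant phenyl would follow chloro or fluoro on the methoxy core. Going by these compounds, it also remains open whether an ethoxy or a hydroxy group in place of methoxy would bring the same dependence.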